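The compounds below may be only part of what the source reports. "The series", "measured", "known", "first", "only" and "open" are said of these compounds alone.

Measured so far, in a functional assay on HeLa S3 cells (Homo sapiens) for antiproliferative activity, read by XTT assay, with a stated time of 72 h; a higher number here means a weaker inhibitor, a lower number a stronger inhibitor:

Compound 1, `COc1ncnc2c1c(-c1cc3ccccc3o1)cn2[C@@H]1O[C@H](CO)[C@@H](O)[C@H]1O`: 9240 nM
Compound 2, `Nc1nc(N)c2c(-c3cc4ccccc4o3)cn([C@@H]3O[C@H](CO)[C@@H](O)[C@H]3O)c2n1`: > 20000 nM, which is a limit of the assay and not a number
Compound 3, `COc1ncnc2c1c(-c1ccco1)cn2[C@@H]1O[C@H](CO)[C@@H](O)[C@H]1O`: 1020 nM

The study has two cores. Compound 1 and compound 3 share one of them; compound 2 and the unmeasured compound 4, `Nc1nc(N)c2c(-c3ccco3)cn([C@@H]3O[C@H](CO)[C@@H](O)[C@H]3O)c2n1`, share the other. How the two cores differ is not broken down here.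

Within the first core, the change furan-2-yl in place of 1-benzofuran-2-yl on an aromatic carbon made the step of a 9.1-fold lower number from compound 1 to compound 3 (0.96 log units; beyond the scatter) in this assay. Compound 4 carries the same change against compound 2, namely (furan-2-yl in place of 1-benzofuran-2-yl on an aromatic carbon), at the same place in the ring system.

For compound 2 only a limit is known, as the limit of > 20000 nM in this assay, at which 1 of the 3 values shown sits, shows, so the starting point of the new step is not fixed. If the change behaves as it did within the first core, compound 4 is expected to land at a lower number than that limit, by a step estimated as an at least 2.5-fold lower number from compound 2 to compound 4 (0.39 log units; beyond the scatter), though it may still come out as a limit. Compound 4 is therefore estimated in this assay at 8000 nM, within 2000 nM to 30000 nM.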

Compound 4, half-maximal inhibitory concentration: > 20000 nM
Compound 4 ended at the assay's limit; the forecaster's own chance of this, stated with the estimate: 35%; middle value at least 2.5-fold (0.39 log units) away from the limit.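

In this assay compound 4 gives > 20000 nM, which is a limit of the assay and not a number. Compound 2 also stands at a limit, so no step between compound 2 and compound 4 can be read: the limit of > 20000 nM in this assay, at which 2 of the 4 values shown sit.

The compounds shown leave open whether furan-2-yl in place of 1-benzofuran-2-yl changes the activity at all on the core shared by compound 2 and compound 4.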